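This account rests on a few compounds, and the source may have more. Where it says the series, first, only, none or still open, it means among the compounds named here.

The measured compounds, with their numbers in a functional assay on Jurkat cells (Homo sapiens) for activation, with a stated time of 24 h; a higher number here means that more compound is needed for the effect, a lower number that less compound is needed:
compound 1 `Oc1ccccc1CNc1ccc(-c2ccccc2)cc1` gives 1820 nM;
compound 2 `Oc1ccccc1CNc1ccc(-c2ccc(F)cc2)cc1` gives 3860 nM;
compound 3 `CCOc1ccc(-c2ccc(NCc3ccccc3O)cc2)cc1` gives 520 nM.

Compound 1 stands second highest of these three numbers in this assay: a 2.1-fold higher number from compound 1 to compound 2 (0.33 log units; beyond the scatter), while a 3.5-fold lower number from compound 1 to compound 3 (0.54 log units; beyond the scatter). The remaining step, a 7.4-fold lower number from compound 2 to compound 3 (0.87 log units; beyond the scatter), is likewise modest. All three measured steps concern one and the same place on the outer phenyl group, where hydrogen is exchanged for fluoro or ethoxy; taken together they show that a single small change there moves the number in this assay modestly, in either direction.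

Compound 4 `Cc1cc(-c2ccccc2)ccc1NCc1ccccc1O` differs from compound 1 in a different place: methyl in place of hydrogen on an aromatic carbon. Among the measured compounds shown here, none of the measured steps touches this place. They bear on the new step only in a general way, as a gauge of how far one small added group has shifted the number. The step from compound 1 to compound 4 in this assay is therefore expected to be small, within or only just beyond the scatter, with no firm direction: a 1.1-fold lower number from compound 1 to compound 4 (0.06 log units; within the scatter). Compound 4 is estimated at 1600 nM, with a range from 500 nM to 5000 nM.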

Compound 4, half-maximal effective concentration: "not active" (no number reported)
For compound 4 the study gives words and no number, and the estimate cannot be compared.
By their numbers in this assay, from the lowest: compound 3; then compound 1; then compound 2.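

In this assay, among the compounds shown here, compound 4 is reported only in words, as not active, with no number, and no step from compound 1 to compound 4 can be read. The compounds shown leave open how far methyl at this place shifts the number. No evidence shown bears on this result.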